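This account rests on a few compounds, and the source may have more. Where it says the series, first, only, none or still open, it means among the compounds named here.

Compound 1 `CCC1CCCN(C(=O)CN2CN(c3ccccc3)C3(CCN(C(=O)c4ccc(C5CCCCC5)cc4)CC3)C2=O)C1` is the reference point of this pair. In an assay on HEK293 cells for displacement of a labelled ligand from NPC1-like intracellular cholesterol transporter 1 (Homo sapiens) (on this read-out lower numbers stand for stronger inhibition and higher numbers for weaker inhibition), compound 1 gives 2600 nM, the lowest of the two numbers at hand. Compound 2 `CC(C)(C)OC(=O)NC1CCCN(C(=O)CN2CN(c3ccccc3)C3(CCN(C(=O)c4ccc(C5CCCCC5)cc4)CC3)C2=O)C1` carries (tert-butoxycarbonyl)amino in place of ethyl on a saturated ring carbon and in this assay compound 2 gives 4400 nM; the step of a 1.7-fold higher number from compound 1 to compound 2 (0.23 log units; within the scatter) shows that this change leaves the number where it was.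

Compound 3 `O=C(CN1CN(c2ccccc2)C2(CCN(C(=O)c3ccc(C4CCCCC4)cc3)CC2)C1=O)NCCCCO` is not yet measured. It differs from compound 1 as follows: (4-hydroxybutyl)amino in place of 3-ethylpiperidin-1-yl on a carbonyl carbon. For the measured compounds named here, the only measured step alters a substituent on the 3-ethylpiperidin-1-yl ring while keeping the ring; the step to compound 3 removes that ring and puts an open (4-hydroxybutyl)amino chain on the carbonyl carbon, so no measured step covers this kind of change. Going by the values given here, the single step available, a 1.7-fold higher number from compound 1 to compound 2 (0.23 log units; within the scatter), is small, which argues that the amide end tolerates variation, but a ring-to-chain exchange is a larger move. For compound 3 the expected step is a 2.1-fold higher number from compound 1 to compound 3 (0.33 log units; beyond the scatter), toward a higher number, with wide uncertainty. The estimate for compound 3 in this assay is 5500 nM, expected to fall between 2000 nM and 16000 nM.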

Compound 3, half-maximal inhibitory concentration: 10300 nM
Compound 3: the middle estimate sits 1.9-fold (0.27 log units) below what was measured, and the stated range covers the measured number.
By their numbers in this assay, from the lowest: compounds 1 and 2 (each within the scatter of the next); then compound 3.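

In this assay, replacing 3-ethylpiperidin-1-yl with (4-hydroxybutyl)amino on a carbonyl carbon gives a 4.0-fold higher number from compound 1 to compound 3 (0.60 log units; beyond the scatter), whereas the change that keeps the ring, a 1.7-fold higher number from compound 1 to compound 2 (0.23 log units; within the scatter), stays within the scatter. The position therefore does not accept every change equally: of the two steps shown, only the one that removes the ring moves the number beyond the scatter, and it does so only modestly. That step also changes several things at once, as the entering group has no ring, contains an oxygen and has 2 hydrogen-bond donors where the leaving group has 0, and nothing at hand separates these differences or gives a reason for the higher number.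

The compounds shown leave open whether the loss of the ring or the presence of the hydroxyl accounts for the step, a question that a plain butylamino chain and a 4-hydroxypiperidin-1-yl group on the same carbonyl carbon would help to separate. They also leave open how a shorter or longer hydroxyalkylamino chain, or a morpholin-4-yl ring, would read in this assay.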